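This account rests on a few compounds, and the source may have more. Where it says the series, first, only, none or still open, it means among the compounds named here.

Measured compounds:
compound 1, `C=CC1=C(C(=O)NCC(C)C)C(c2ccc(F)cc2)OC1`, > 100000 nM
compound 2, `C=CC1=C(C(=O)Nc2ccc(OCC)cc2)C(c2ccc(OC)cc2)OC1`, > 100000 nM
compound 3, `C=CC1=C(C(=O)NCCC)C(c2ccc(OC)c(OC)c2)OC1`, > 100000 nM

Three compounds sharing one core were tested in a functional assay on QGY7701 cells (Homo sapiens) for cytotoxicity, read by MTT assay, with a stated time of 24 h; a lower number here means a stronger inhibitor, a higher number a weaker inhibitor. Compound 1 gives only a limit there, > 100000 nM, and not a number. Compound 2 likewise reaches only the limit > 100000 nM. Compound 3 also stops at the limit > 100000 nM. Thus every measured value sits at the limit of > 100000 nM in this assay, at which 3 of the 3 values shown sit, and compound 1 stands nowhere apart from the others: none of the three shows measurable activity, and no order among them can be read.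

Compound 4, `C=CC1=C(C(=O)NCc2ccccc2)C(c2ccc(F)cc2)OC1`, remains to be measured. It differs from compound 1 by phenyl in place of isopropyl on a saturated chain carbon bound to an amide-type nitrogen. Within the data shown here, no measured pair shows a change at this position, so there is no step from which to read a direction. Since compound 1 and its two companions all sit at the limit, the step from isobutylamino to benzylamino is expected to stay within the scatter or to leave the value at the limit. The step that the limit leaves unreadable from compound 1 to compound 4 is therefore estimated to be small. Compound 4 is expected to give about 150000 nM, within a range from 40000 nM to 500000 nM.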

Compound 4, half-maximal inhibitory concentration: 67600 nM
For compound 4 the middle estimate is 2.2-fold (0.35 log units) above the measured one; the measured number falls inside the stated range.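

In this assay, phenyl in place of isopropyl on a saturated chain carbon bound to an amide-type nitrogen gives an at least 1.4-fold lower number from compound 1 to compound 4 (0.17 log units; that floor lies within the scatter), and compound 4 is the only compound shown with a number rather than a limit. Among these compounds, this is the first reading at this place, and it shows that a value can be obtained there with the benzyl group. The true size of the step cannot be fixed, and its printed floor alone does not set it beyond the scatter, because the starting point is a limit: the limit of > 100000 nM in this assay, at which 3 of the 4 values shown sit.

As far as these compounds go, what a longer chain, a cyclohexyl group or a pyridine ring would give in place of phenyl remains open. From the compounds shown here alone, it is also open whether a carboxylic acid or an amine on the phenyl ring of the benzyl group would move the value at all.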